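The source may hold more compounds than are shown below. What is called first, only, known or untested is meant among the compounds shown, and "the series" means these compounds.

Measured compounds in an assay on HEK293 cells for displacement of a labelled ligand from Orexin receptor type 2 (Homo sapiens), read by scintillation counting, with a stated time of 90 min; on this read-out lower numbers stand for stronger inhibition and higher numbers for weaker inhibition:
- compound 1 `COc1ccc(N2C(=O)N(Cc3c(F)cc(F)cc3OC)c3ccccc3S2(=O)=O)cc1OC`: 6.31 nM
- compound 2 `COc1cc(F)c(CN2C(=O)N(c3cnc(OC)c(OC)c3)S(=O)(=O)c3ccccc32)c(F)c1`: 0.398 nM
- compound 3 `COc1cc(F)c(CN2C(=O)N(c3cc(OC)nc(OC)c3)S(=O)(=O)c3ccccc32)c(F)c1`: 0.251 nM

Compound 1 gives the highest number of the three, so it is the weakest binder here; compound 2 reads a clearly lower number, and compound 3 lower still. Among the compounds with values here, the only one-place step among the measured compounds is a 1.6-fold lower number from compound 2 to compound 3 (0.20 log units; within the scatter), which concerns the ring on the amide-type nitrogen and leaves no measurable mark.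

Compound 4 `COc1ccc(N2C(=O)N(Cc3c(F)cccc3Cl)c3ccccc3S2(=O)=O)cc1OC` is not yet measured. It differs from compound 1 at the other end of the shared core: 2-chloro-6-fluorophenyl in place of 2,4-difluoro-6-methoxyphenyl on a saturated chain carbon bound to an amide-type nitrogen in a ring. Within the data shown here, no measured pair tracks this change, and the step from compound 2 to compound 3 touches a different part of the molecule, so it gives no guide to the size or direction of the effect. With nothing to point one way or the other, compound 4 is expected to land near compound 1, a step of a 1.6-fold higher number from compound 1 to compound 4 (0.20 log units; within the scatter) in this assay, with wide uncertainty. The estimate for compound 4 is 10 nM, within a range of 2.5 nM to 40 nM.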

Compound 4, inhibition constant: 0.794 nM
Estimate against measurement, compound 4: 13-fold (1.10 log units) above; measured number below the stated range.
By their numbers in this assay, from the lowest: compounds 3, 2 and 4 (each within the scatter of the next, the first and the last beyond it); then compound 1.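

In this assay, putting 2-chloro-6-fluorophenyl in place of 2,4-difluoro-6-methoxyphenyl on a saturated chain carbon bound to an amide-type nitrogen in a ring gives a 7.9-fold lower number from compound 1 to compound 4 (0.90 log units; beyond the scatter) and shows that the number responds to what this position carries. Within the data shown here, the only earlier step changed the ring at the other end of the shared core and stayed within the scatter, so this is the first single change here to move the number beyond it. Nothing measured explains the step, and with a methoxy group leaving and a chlorine entering together, the part that matters cannot be singled out.

As far as these compounds go, it remains open whether the chlorine or the loss of the methoxy group carries the step. Also open, from the compounds shown here alone, is how this position would read with an amine or a nitrile on the ring, or with a longer chain joining that ring to the core.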